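The source may hold more compounds than are shown below. What is called first, only, known or untested is meant among the compounds shown, and "the series" means these compounds.

Measured so far:
compound 1 `CN(Cc1cccc(F)c1)C(=O)CNC(=O)c1ccc(S(C)(=O)=O)c([N+](=O)[O-])c1`: > 60000 nM
compound 2 `CS(=O)(=O)c1ccc(C(=O)NCCCC(=O)N2Cc3ccccc3C2)cc1[N+](=O)[O-]`: > 60000 nM
compound 3 `CN(CC(=O)N1CCN(c2ccc(F)cc2)CC1)C(=O)c1ccc(S(C)(=O)=O)c([N+](=O)[O-])c1`: > 60000 nM

All three of these values were obtained in an assay on isolated protein for inhibition of vitamin D3 receptor (Homo sapiens), read by fluorescence polarization; on this read-out lower numbers stand for stronger inhibition and higher numbers for weaker inhibition. For compound 1 the value given is a limit of the assay, not a number. For compound 2 the value given is likewise a limit and not a number. For compound 3 the same holds. Compound 2 therefore cannot be placed above or below the other two on the numbers shown: every value sits at the same limit, which is recorded as the limit of > 60000 nM in this assay, at which 3 of the 3 values shown sit. Going by the values given here, no step between any two of the measured compounds is known, so no size of step can be read from them.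

Compound 4 `CN(Cc1cccc(F)c1)C(=O)CCCNC(=O)c1ccc(S(C)(=O)=O)c([N+](=O)[O-])c1` has not yet been measured in this assay. It differs from compound 2 in a single place: a group of 10 heavy atoms (8 carbon, 1 nitrogen, 1 fluorine; one six-membered aromatic ring of carbon only) in place of a group of 9 heavy atoms (8 carbon, 1 nitrogen; one five-membered non-aromatic ring with 1 hetero atom, one six-membered aromatic ring of carbon only), on a carbonyl carbon.

Because all three measured values sit at the limit of > 60000 nM in this assay, at which 3 of the 3 values shown sit, there is no numerical foothold for this change. The expectation is a step from compound 2 to compound 4 of a step that the limit leaves unreadable from compound 2 to compound 4, that is, none beyond the usual scatter, with the result most likely again a limit. Compound 4 is thus estimated to give about 100000 nM in this assay, within a range from 30000 nM to 400000 nM.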

Compound 4, half-maximal inhibitory concentration: > 60000 nM
Compound 4: no number, only a limit (the forecaster's own chance of this, stated with the estimate: 85%); the middle value lies beyond the limit too.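

In this assay compound 4 gives > 60000 nM, which is a limit of the assay and not a number. No step from compound 2 to compound 4 can be read, because both compounds sit at the same limit: the limit of > 60000 nM in this assay, at which 4 of the 4 values shown sit.

The compounds shown leave open how strongly any of them inhibits the receptor, and whether exchanging the group on the carbonyl carbon changes that inhibition at all.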